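Moving a Methoxy Group and Membrane Permeability

The compounds below may be only part of what the source reports. "The series", "measured", "known", "first", "only" and "open" are said of these compounds alone.

Compound 1 `COc1ccccc1Oc1ccc2c(NCCCNCc3ccco3)ccnc2c1` has been measured in an ADME assay for permeability, using PAMPA, with a stated time of 30 min, at pH 7.4 (on this read-out lower numbers stand for lower permeability and higher numbers for higher permeability), where compound 1 gives 317 10^-6 cm/s, the higher of the two numbers seen so far. The other measured compound, compound 2 `COc1cccc(CNCCCNc2ccnc3cc(Cc4ccccc4)ccc23)c1O`, gives 23 10^-6 cm/s in this assay, a gap well beyond the usual scatter. Compound 3 `COc1ccc(Oc2ccc3c(NCCCNCc4ccco4)ccnc3c2)cc1` is not yet measured. It differs from compound 1 by one rearrangement: 4-methoxyphenyl in place of 2-methoxyphenyl on an oxygen on an aromatic ring. Since the same atoms are simply joined differently, the expected step of a 1.2-fold lower number from compound 1 to compound 3 (0.09 log units; within the scatter) should stay within the scatter. Compound 3 is therefore expected to give about 260 10^-6 cm/s, somewhere between 120 10^-6 cm/s and 520 10^-6 cm/s.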

Compound 3, apparent permeability: 317 10^-6 cm/s
Beside the measured number, compound 3's estimate is 1.2-fold (0.09 log units) below it; low and high end bracket the measured number.
By their numbers in this assay, from the lowest: compound 2; then compounds 1 and 3 (each within the scatter of the next).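

Putting 4-methoxyphenyl in place of 2-methoxyphenyl on an oxygen on an aromatic ring leaves the number in this assay unmoved, with no change at the digits printed from compound 1 to compound 3 (within the scatter). Going by these compounds alone, compounds 1 and 3 thus form the first pair that differs in one place, and this read-out does not separate these two methoxyphenyl groups on the shared core. Nothing available explains this result. Still open, on these data alone, is whether the number would hold if an amine or a carboxylic acid replaced the methoxy group on this ring.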